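The compounds below may be only part of what the source reports. "The series", "measured", "known", "first", "only" and "open" are said of these compounds alone.

Measured so far in an ADME assay on L02 cells (Homo sapiens) for inhibition, read by CCK-8 assay, with a stated time of 48 h; a lower number here means a stronger inhibitor of growth, a higher number a weaker inhibitor of growth:

- compound 1 `Cc1ccccc1Nc1nc(NC2CC2)ncc1Cl`: compound 1 gives > 100000 nM, a limit of the assay.
- compound 2 `Cc1ccccc1Nc1nc(Nc2ccc(N3CCCCC3)cn2)ncc1Cl`: compound 2 gives 42400 nM.
- compound 3 `Cc1ccc(CNc2nc(Nc3ccc(N4CCN(C)CC4)cn3)ncc2Cl)cc1`: compound 3 gives > 100000 nM, again a limit of the assay.

Within the data shown here, compound 3 therefore stands at the limit of > 100000 nM in this assay, at which 2 of the 3 values shown sit, so its own value is not a number but only a limit, and no measured step can be drawn from it. Among the measured compounds shown here, of the shared core bearing the methylpiperazinyl pyridine, compound 3 is the only example with a number of any kind; compound 2, with the piperidinyl pyridine in its place, is the single compound of the three with a value inside the measured range.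

The next compound, compound 4 `CC(C)c1ccc(Nc2nc(Nc3ccc(N4CCN(C)CC4)cn3)ncc2Cl)cc1`, differs from compound 3 in one place: 4-isopropylphenyl in place of 4-methylbenzyl on a nitrogen on an aromatic ring. In this assay, for the measured compounds named here, compound 4 is expected to inhibit growth at most moderately more than compound 3, since compound 2, the one measured anilino analogue, lies not far inside the range with 42400 nM. The step from compound 3 to compound 4 is thus estimated as an at least 1.6-fold lower number from compound 3 to compound 4 (0.22 log units; that floor lies within the scatter), small and toward stronger inhibition, with a real chance that the assay again returns only a limit. For compound 4 the estimate is 60000 nM, within 20000 nM to 120000 nM.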

Compound 4, concentration for 50% growth inhibition: 13700 nM
Compound 4: the middle estimate sits 4.4-fold (0.64 log units) above what was measured, and the stated range ends above it.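

In this assay, 4-isopropylphenyl in place of 4-methylbenzyl on a nitrogen on an aromatic ring gives an at least 7.2-fold lower number from compound 3 to compound 4 (0.86 log units; beyond the scatter). Among these compounds, this is the first step that can be read, and it lies beyond the scatter. It is only a floor, and its true size stays unknown, as compound 3 sits at a limit of the assay: the limit of > 100000 nM in this assay, at which 2 of the 4 values shown sit.

With the rest of the molecule unchanged, this one swap brings compound 4 to 13700 nM, inside the measured range, so growth inhibition in these cells responds to the group at this position.

Two things change together in this swap: the carbon link between the nitrogen and the ring is lost, and methyl gives way to isopropyl, and the compounds shown do not separate the two. Also open, on these data alone, is how this position would read with a plain phenyl, or with a phenyl carrying an amine or a carboxylic acid, and whether the step would hold on the shared core with a different group on the pyridine.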